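The source may report more compounds than this note shows. Statements on the series, on what has been measured and on what is new or still open speak of the compounds shown alone.

Working notes on the series. In a physicochemical assay for solubility, read by nephelometry, at pH 7.4 (on this read-out lower numbers stand for lower solubility and higher numbers for higher solubility), compound 1 `COc1cccc(NC(=O)c2nnn(CC3CCNCC3)c2N)c1` reads > 250000 nM, which is a limit and not a number. Compound 2 `COc1cccc(NC(=O)c2nnn(Cc3ccccc3)c2N)c1` gives 16000 nM. Compound 3 `COc1cccc(NC(=O)c2nnn(Cc3ccc(-n4cccn4)cc3)c2N)c1` gives 20000 nM, which places it within the scatter of compound 2.

The change to compound 4 `COc1cccc(NC(=O)c2nnn(Cc3ccc(C4CC4)cc3)c2N)c1` is cyclopropyl in place of 1H-pyrazol-1-yl on an aromatic carbon, para to a large group.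

Two measured steps are available. The one at this same place is a 1.3-fold higher number from compound 2 to compound 3 (0.10 log units; within the scatter), and it lies within the scatter. The other is an at least 15-fold lower number from compound 1 to compound 2 (1.19 log units; beyond the scatter), which is large but sits at a different place, on a saturated chain carbon bound to an aromatic nitrogen, so it offers little guidance here. No step beyond the scatter is therefore expected in this assay. The expected change is a 1.4-fold lower number from compound 3 to compound 4 (0.15 log units; within the scatter). For compound 4 the estimated value is 14000 nM, with an expected range of 5000 nM to 32000 nM.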

Compound 4, solubility: 79000 nM
Estimate against measurement, compound 4: 5.6-fold (0.75 log units) below; the measured number lies above the stated range.
By their numbers in this assay, from the lowest: compounds 2 and 3 (each within the scatter of the next); then compound 4. At a limit, above all of these: compound 1.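

In this assay this place, on an aromatic carbon para to a large group, turns out to move the read-out: cyclopropyl gives a 4.9-fold higher number from compound 2 to compound 4 (0.69 log units; beyond the scatter) and a 4.0-fold higher number from compound 3 to compound 4 (0.60 log units; beyond the scatter) with both steps beyond the scatter. The earlier step here, from hydrogen to 1H-pyrazol-1-yl, lay within the scatter, so that flat result does not hold for every group at this place. The change on the saturated chain carbon remains the larger lever, with an at least 3.1-fold lower number from compound 1 to compound 4 (0.50 log units; beyond the scatter) still separating the two compounds, and that step rests on a limit and not a number: the limit of > 250000 nM in this assay, at which 1 of the 4 values shown sits.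

Only hydrogen, 1H-pyrazol-1-yl and cyclopropyl are shown at this place, so it stays open whether the higher number is particular to cyclopropyl. An amine, a carboxylic acid or a longer chain here would show how far this place can carry the read-out.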